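This account rests on a few compounds, and the source may have more. Where it says the series, first, only, none or still open, it means among the compounds named here.

Compound 1 `OCC#CCSc1cnc2ccccc2c1[Se]CC#CCBr`, compound 2 `OCC#CCSc1cnc2ccccc2c1SCC#CCO` and compound 3 `C#CCSc1c(SCC#CCO)cnc2ccccc12` were each tested in a functional assay on P388 cells (Mus musculus) for cytotoxicity, read by MTT assay, with a stated time of 72 h; on this read-out lower numbers stand for stronger inhibition and higher numbers for weaker inhibition. Compound 1 gives 1.6 ug/mL, compound 2 gives 5.7 ug/mL and compound 3 gives 13.3 ug/mL. The step of a 3.6-fold higher number from compound 1 to compound 2 (0.55 log units; beyond the scatter) and the step of an 8.3-fold higher number from compound 1 to compound 3 (0.92 log units; beyond the scatter) leave compound 1 with the lowest number of the three. The change hydrogen in place of hydroxymethyl on a triple-bonded carbon occurs twice among these compounds; on the core of compound 2 it made the step of a 2.3-fold higher number from compound 2 to compound 3 (0.37 log units; beyond the scatter). Compound 4 `C#CCSc1cnc2ccccc2c1[Se]CC#CCBr` carries the same change on the core of compound 1, namely (hydrogen in place of hydroxymethyl on a triple-bonded carbon). The two cores differ in that (a group of 6 heavy atoms (4 carbon, 1 selenium, 1 bromine; no ring) in place of a group of 6 heavy atoms (4 carbon, 1 oxygen, 1 sulfur; no ring), on an aromatic carbon). With a single earlier case to rest on, a step of similar size is expected for compound 4, a 2.3-fold higher number from compound 1 to compound 4 (0.36 log units; beyond the scatter), because compound 2 to compound 3 gave a 2.3-fold higher number from compound 2 to compound 3 (0.37 log units; beyond the scatter). Compound 4 is therefore estimated at 3.7 ug/mL, between 1.8 ug/mL and 7.5 ug/mL.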

Compound 4, concentration for 50% inhibition: 1.2 ug/mL
For compound 4 the middle estimate is 3.1-fold (0.49 log units) above the measured one; the whole stated range lies above it.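

In this assay, putting hydrogen in place of hydroxymethyl on a triple-bonded carbon gave a 1.3-fold lower number from compound 1 to compound 4 (0.12 log units; within the scatter), so on the core of compound 1 this change leaves no readable difference. The change therefore does not carry over at one size from core to core: the same change on two cores in this assay, a 2.3-fold higher number (0.37 log units; beyond the scatter) from compound 2 to compound 3 and a 1.3-fold lower number (0.12 log units; within the scatter) from compound 1 to compound 4, 3.1-fold (0.49 log units) apart, beyond the scatter of two such steps

Within the data shown here, with only two pairs, this does not show which feature of the two cores sets the steps apart, nor how the change behaves on any other core. As far as these compounds go, the two cores differ in selenium and bromine together, so it remains open whether one of them alone matters. Also open, from the compounds shown here alone, is what an amine or a longer chain in place of hydroxymethyl would do on either core.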